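A few compounds are considered here, and "the series" means these few. Any claim that something is new, unique, unknown or untested is made for them only; others in the source may bear on it.

In an ADME assay on microsomes from liver (Mus musculus) for metabolic stability, with a stated time of 10 min (a lower number here means that less of the compound is left, a higher number that more of the compound is left), compound 1 `O=C(O)[C@H]1CC[C@H](C(=O)N2CC[C@](c3ccc(C(F)(C(F)(F)F)C(F)(F)F)cc3)(S(=O)(=O)c3ccccc3)C2)CC1` gives 96% and compound 2 `O=C(O)[C@H]1CC[C@H](C(=O)N2CC[C@](c3ccc(C(F)(C(F)(F)F)C(F)(F)F)cc3)(S(=O)(=O)c3ccc(Cl)cc3)C2)CC1` gives 100%. Compound 3 `Cc1cc(S(=O)(=O)[C@@]2(c3ccc(C(F)(C(F)(F)F)C(F)(F)F)cc3)CCN(C(=O)[C@H]3CC[C@H](C(=O)O)CC3)C2)ccc1F` gives 84%, the lowest of the three numbers. Compound 4 `O=C(O)[C@H]1CC[C@H](C(=O)N2CC[C@](c3ccc(C(F)(C(F)(F)F)C(F)(F)F)cc3)(S(=O)(=O)c3ccc(F)c(C4CC4)c3)C2)CC1` carries cyclopropyl in place of methyl on an aromatic carbon, ortho to a fluoro group: cyclopropyl in place of methyl on an aromatic carbon. Among the measured compounds shown here, no measured step makes this exact change. The nearest guides are the two steps that introduce the 4-fluoro-3-methylphenyl group, a number 12 percentage points lower from compound 1 to compound 3 (beyond the scatter) and a number 16 percentage points lower from compound 2 to compound 3 (beyond the scatter), both modest, while a number 4 percentage points higher from compound 1 to compound 2 (within the scatter) elsewhere on the same aromatic ring stays within the scatter. In this assay the expected change is therefore no larger than those modest steps and leans downward, with an estimated a number 8 percentage points lower from compound 3 to compound 4 (within the scatter). For compound 4 the estimate is 76%, within an expected range from 60% to 92%.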

Compound 4, percent of the compound remaining: 74%
Beside the measured number, compound 4's estimate is 2 percentage points above it; measured number inside the range.
By their numbers in this assay, from the lowest: compounds 4 and 3 (each within the scatter of the next); then compounds 1 and 2 (each within the scatter of the next).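

In this assay, cyclopropyl in place of methyl on this aromatic carbon, ortho to a fluoro group, gives a number 10 percentage points lower from compound 3 to compound 4 (within the scatter) and so stays within the scatter despite the added ring. Set against the phenyl and 4-chlorophenyl groups, the 3-cyclopropyl-4-fluorophenyl group gives a number 22 percentage points lower from compound 1 to compound 4 (beyond the scatter) and a number 26 percentage points lower from compound 2 to compound 4 (beyond the scatter) in the same assay. Nothing available explains these steps.

Going by these compounds, whether a methoxy group or an amine on this carbon would behave like methyl or cyclopropyl stays open. So does the effect of cyclopropyl on this ring without the fluoro group.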